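From 4-nitrobenzyl to 3-phenylpropyl on the sulfur

The source may report more compounds than this note shows. Statements on the series, on what has been measured and on what is new or still open speak of the compounds shown alone.

Compound 1 `Cc1cc(N2CC[C@@H](C)[C@@H](N(C)c3ncnc4[nH]ccc34)C2)n2nc(SCC3CC3)nc2n1` gives 36500 nM
Compound 2 `Cc1ccc(CSc2nc3nc(C)cc(N4CC[C@@H](C)[C@@H](N(C)c5ncnc6[nH]ccc56)C4)n3n2)cc1` gives 69500 nM
Compound 3 `Cc1cc(N2CC[C@@H](C)[C@@H](N(C)c3ncnc4[nH]ccc34)C2)n2nc(SCc3ccc([N+](=O)[O-])cc3)nc2n1` gives 59600 nM

These three values come from a functional assay on BGC-823 cells (Homo sapiens) for inhibition, read by MTT assay, with a stated time of 72 h (a higher number here means a weaker inhibitor, a lower number a stronger inhibitor), and show no separation beyond the scatter. Compound 3 stands within the scatter of both others (a 1.2-fold lower number from compound 2 to compound 3 (0.07 log units; within the scatter)) (a 1.6-fold higher number from compound 1 to compound 3 (0.21 log units; within the scatter)). Compound 4 `Cc1cc(N2CC[C@@H](C)[C@@H](N(C)c3ncnc4[nH]ccc34)C2)n2nc(SCCCc3ccccc3)nc2n1` differs from it in one group (phenethyl in place of 4-nitrophenyl on a saturated chain carbon bound to a sulfur): phenethyl in place of 4-nitrophenyl on a saturated chain carbon bound to a sulfur. The bearing evidence is the exchange of groups in that same place, cyclopropyl to 4-methylphenyl (a 1.9-fold higher number from compound 1 to compound 2 (0.28 log units; within the scatter)), together with the two steps above. All stayed within the scatter, though none tests 3-phenylpropyl. No step beyond the scatter is therefore expected in this assay (a 1.2-fold lower number from compound 3 to compound 4 (0.08 log units; within the scatter)). Compound 4 is estimated at 50000 nM (expected range 25000 nM to 100000 nM).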

Compound 4, half-maximal inhibitory concentration: > 100000 nM
Compound 4 ended at the assay's limit; the forecaster's own chance of this, stated with the estimate: 15%; middle value at least 2.0-fold (0.30 log units) away from the limit.
By their numbers in this assay, from the lowest: compounds 1, 3 and 2 (each within the scatter of the next). At a limit, above all of these: compound 4.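

In this assay, compound 4 gives a limit and not a number: the limit of > 100000 nM in this assay, at which 1 of the 4 values shown sits. Even so, this position now shows its first step beyond the scatter, with 3-phenylpropyl on the sulfur: an at least 2.7-fold higher number from compound 1 to compound 4 (0.43 log units; beyond the scatter). The other two steps, an at least 1.6-fold higher number from compound 3 to compound 4 (0.22 log units; that floor lies within the scatter) and an at least 1.4-fold higher number from compound 2 to compound 4 (0.15 log units; that floor lies within the scatter), have floors within the scatter, so they establish no separation.

From the compounds shown here alone, how far beyond the limit compound 4 lies remains open. Going by these compounds, an unsubstituted benzyl could separate the chain from the ring substituent, and an amine or a carboxylic acid on this saturated chain carbon bound to a sulfur remains untested here.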